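The source may hold more compounds than are shown below. What is called first, only, known or untested is meant among the compounds shown, and "the series" means these compounds.

Measured so far in an assay on isolated protein for inhibition of ubiquitin carboxyl-terminal hydrolase 7 (Homo sapiens), with stated times of 30 min and 2 h; a higher number here means a weaker inhibitor, a lower number a stronger inhibitor:
compound 1, `CC(=O)NCc1ccc(-c2c3ncn(CC4(O)CCN(Cc5ccc(-c6ccco6)cc5Cl)CC4)c(=O)c3nn2C)cc1`, gives 46.1 nM;
compound 2, `Cn1nc2c(=O)n(CC3(O)CCN(Cc4ccc(-c5ccsc5Cl)cc4Cl)CC3)cnc2c1-c1ccc(CN)cc1`, gives 453 nM;
compound 3, `Cn1nc2c(=O)n(CC3(O)CCN(Cc4ccc(-c5ccc[nH]5)cc4Cl)CC3)cnc2c1-c1ccc(CN)cc1`, gives 193 nM.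

Compound 3 stands second highest of the three numbers; compound 2 lies above it and compound 1 well below it. The next compound, compound 4, is `Cn1nc2c(=O)n(CC3(O)CCN(Cc4ccc(-c5ccco5)cc4Cl)CC3)cnc2c1-c1ccc(CN)cc1`. It differs from compound 3 in one place: furan-2-yl in place of 1H-pyrrol-2-yl on an aromatic carbon. Going by the values given here, the one step that bears on this position is a 2.3-fold lower number from compound 2 to compound 3 (0.37 log units; beyond the scatter), a modest move beyond the scatter. Among the compounds with values here, compound 1, which also carries furan-2-yl at this position but differs elsewhere as well, gives 46.1 nM against compound 3 with 193 nM; no single step links the two. A modest downward move is therefore expected in this assay, estimated as a 1.8-fold lower number from compound 3 to compound 4 (0.24 log units; within the scatter). Compound 4 is expected to give 110 nM, within 45 nM to 280 nM.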

Compound 4, half-maximal inhibitory concentration: 18.1 nM
Beside the measured number, compound 4's estimate is 6.1-fold (0.78 log units) above it; the measured number lies below the stated range.
By their numbers in this assay, from the lowest: compound 4; then compound 1; then compound 3; then compound 2.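

At this position the identity of the five-membered aromatic ring matters far more than the earlier step suggested: furan-2-yl gives an 11-fold lower number from compound 3 to compound 4 (1.03 log units; beyond the scatter) in this assay, and a 25-fold lower number from compound 2 to compound 4 (1.40 log units; beyond the scatter), so the exchange of nitrogen for oxygen alone is a large step. With furan-2-yl held constant, the free amine also improves on the acetyl amide, with a 2.5-fold lower number from compound 1 to compound 4 (0.41 log units; beyond the scatter), a modest step. No measurement shown accounts for the gap between furan-2-yl and 1H-pyrrol-2-yl. Still open, as far as these compounds go, is whether thiophen-2-yl or a methyl-substituted furan would match compound 4 in this assay.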